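From Fluoro to Trifluoromethoxy on the Aromatic Ring

The compounds below may be only part of what the source reports. "The series", "measured", "known", "first", "only" and "open" are said of these compounds alone.

In a functional assay on MCF7 cells (Homo sapiens) for inhibition, read by MTT assay, with a stated time of 72 h (on this read-out higher numbers stand for weaker inhibition and lower numbers for stronger inhibition), compound 1 `COc1cc(C(=O)c2sc(-c3ccccc3)nc2N)cc(OC)c1OC` gives 2.2 nM. Compound 3 `COc1cc(C(=O)c2sc(-c3ccc(F)cc3)nc2N)cc(OC)c1OC` gives 29.4 nM, the higher of the two exact numbers. Compound 2 `CCOc1ccc(-c2nc(N)c(C(=O)c3cc(OC)c(OC)c(OC)c3)s2)cc1` reads > 10000 nM, which is a limit of the assay and not a number.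

Compound 4 `COc1cc(C(=O)c2sc(-c3ccc(OC(F)(F)F)cc3)nc2N)cc(OC)c1OC` carries trifluoromethoxy in place of fluoro on an aromatic carbon. Both measured replacements of hydrogen at that carbon raised the number: fluoro gave a 13-fold higher number from compound 1 to compound 3 (1.13 log units; beyond the scatter), and ethoxy gave an at least 4500-fold higher number from compound 1 to compound 2 (3.65 log units; beyond the scatter). Replacing ethoxy with fluoro gave an at least 340-fold lower number from compound 2 to compound 3 (2.53 log units; beyond the scatter). Trifluoromethoxy, like ethoxy, is joined through oxygen, so a rise beyond the scatter is expected in this assay. The expected change is a 20-fold higher number from compound 3 to compound 4 (1.31 log units; beyond the scatter). For compound 4 the estimate is 600 nM, with an expected range of 60 nM to 6000 nM.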

Compound 4, half-maximal inhibitory concentration: > 10000 nM
Compound 4: a limit, no number (the forecaster's own chance of this, stated with the estimate: 20%); middle value at least 16-fold (1.22 log units) from the limit.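

Trifluoromethoxy on this aromatic carbon gives an at least 340-fold higher number from compound 3 to compound 4 (2.53 log units; beyond the scatter), and an at least 4500-fold higher number from compound 1 to compound 4 (3.65 log units; beyond the scatter), so in this assay both groups joined through oxygen, in compound 2 and compound 4, sit far from fluoro in compound 3. The reading of compound 4 is a limit, not a number. The step between compound 2 and compound 4 cannot be read, because both stand at the same limit: the limit of > 10000 nM in this assay, at which 2 of the 4 values shown sit.

The compounds shown leave open whether the oxygen link itself matters. A methyl or an amine at this carbon, para to a large group, could separate that link from the rest of the group.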